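From compound 2 to compound 3: a longer chain

The source may hold more compounds than are shown below. What is called first, only, known or untested is meant among the compounds shown, and "the series" means these compounds.

Measured so far in a functional assay on A549 cells (Homo sapiens) for inhibition, with a stated time of 48 h, tested at 50 uM; on this read-out higher numbers stand for more inhibition of growth at the one concentration tested and lower numbers for less inhibition of growth:
- compound 1 `C=C[C@@](C)(/C=C/c1ccc(OC(C)=O)cc1)CCC=C(C)C`: 72%
- compound 2 `C=C[C@@](C)(/C=C/c1ccc(OC(=O)CCCCC)cc1)CCC=C(C)C`: 58%

Of these two compounds, compound 2 stands lowest. Compound 3 `C=C[C@@](C)(/C=C/c1ccc(OC(=O)CCCCCCCCC)cc1)CCC=C(C)C` has not yet been measured and differs from compound 2 by butyl in place of hydrogen on a saturated chain carbon, five bonds along the chain from a carbonyl carbon. For the measured compounds named here, one measured step bears on this change: butyl in place of hydrogen on a saturated chain carbon bound to a carbonyl carbon gave a number 14 percentage points lower from compound 1 to compound 2 (beyond the scatter) in this assay. A single step is thin ground and establishes no pattern. The expected change, in the same direction and of similar size, is a number 12 percentage points lower from compound 2 to compound 3 (beyond the scatter) in this assay. Compound 3 is therefore estimated at 46% (expected range 28% to 62%) on this reasoning.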

Compound 3, percent growth inhibition at one concentration: 48%
Estimate against measurement, compound 3: 2 percentage points below, within the range that was stated.
By their numbers in this assay, from the lowest: compounds 3 and 2 (each within the scatter of the next); then compound 1.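

In this assay the butyl added at this place, five bonds along the chain from the carbonyl carbon, gave a number 10 percentage points lower from compound 2 to compound 3 (within the scatter), so this extension cannot be separated from compound 2 on this read-out. Only the whole octyl change holds beyond the scatter, with a number 24 percentage points lower from compound 1 to compound 3 (beyond the scatter). Nothing available explains the effect of chain length at this position.

As far as these compounds go, what a still longer chain would give stays open, as does the effect of an amine or a carboxylic acid placed on the chain.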